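The compounds below may be only part of what the source reports. "The series", "measured", "known", "first", "only" and "open" are said of these compounds alone.

Working notes on the series. Compound 1 `Cc1ccc(C)c(S(=O)(=O)N(C)/N=C/c2cnn3ccc(C#N)cc23)c1` is the starting point. In an assay on isolated protein for inhibition of phosphatidylinositol 4,5-bisphosphate 3-kinase catalytic subunit beta isoform (Homo sapiens), read by 33P incorporation, with a stated time of 60 min (a lower number here means a stronger inhibitor, a higher number a weaker inhibitor), compound 1 gives only a limit, > 1000 nM, and this is the limit of > 1000 nM in this assay, at which 1 of the 3 values shown sits. Compound 2 `CN(C)c1ccc([N+](=O)[O-])cc1S(=O)(=O)N(C)/N=C/c1cnn2ccc(C#N)cc12` gives 44 nM in this assay. Compound 3 `CN(/N=C/c1cnn2ccc(C#N)cc12)C(=O)c1cccc([N+](=O)[O-])c1` gives 67 nM in this assay. Within the data shown here, no step between measured compounds is available here, so the values of compounds 2 and 3 stand on their own and say nothing about the step under study.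

Compound 4 `CC(=O)Nc1ccc(C)c(S(=O)(=O)N(C)/N=C/c2cnn3ccc(C#N)cc23)c1` differs from compound 1 in one place: acetamido in place of methyl on an aromatic carbon. Since compound 1 sits at a limit, the size of the step can only be bounded from one side. A moderate move toward stronger inhibition is expected, but with wide uncertainty. The value expected for compound 4 in this assay is 600 nM, with a range from 150 nM to 3000 nM. The step this estimate implies is an at least 1.6-fold lower number from compound 1 to compound 4 (0.22 log units; that floor lies within the scatter), and it remains an expectation only.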

Compound 4, half-maximal inhibitory concentration: > 1000 nM
Compound 4: only a limit was reported; the forecaster's own chance of this, stated with the estimate: 40%; at least 1.6-fold (0.22 log units) between middle value and limit.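

Compound 1 and compound 4 both stand at a limit, so no step can be read between them: the limit of > 1000 nM in this assay, at which 2 of the 4 values shown sit.

From the compounds shown here alone, whether acetamido in place of methyl on an aromatic carbon changes inhibition at all, and in which direction, remains open.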